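This account rests on a few compounds, and the source may have more. Where it says the series, first, only, none or still open, it means among the compounds named here.

Working notes on the series in a functional assay on HOS-TE85 cells (Homo sapiens) for inhibition, read by CCK-8 assay, with a stated time of 72 h, tested at 1 uM; a higher number here means more inhibition at the concentration tested (going by the name of the read-out), a lower number less inhibition. Compound 1 `COc1ccccc1N1C(=O)C(C)SC1c1cccc(C(=O)NCCCCc2ccccc2)c1` gives 95%. Compound 2 `COc1cc(F)ccc1N1C(=O)CSC1c1cccc(C(=O)NCCCCc2ccccc2)c1` gives 94%, a number within the scatter of that of compound 1, so the two cannot be told apart here. Compound 3 `COc1ccc(N2C(=O)CSC2c2cccc(C(=O)NCCCCc3ccccc3)c2)c(OC)c1` has not been run yet; it differs from compound 2 as follows: methoxy in place of fluoro on an aromatic carbon. Going by the values given here, no comparable measured step is at hand. Because compound 2 sits at 94%, compound 3 is expected to stay near that level, with a step of a number 4 percentage points lower from compound 2 to compound 3 (within the scatter) not beyond the scatter. The estimate for compound 3 is 90%, with a range from 75% to 98%.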

Compound 3, a percentage reported as inhibition, at one concentration (the size of the read-out at that concentration, not a potency): 58%
Estimate against measurement, compound 3: 32 percentage points above, and the stated range ends above it.
By their numbers in this assay, from the lowest: compound 3; then compounds 2 and 1 (each within the scatter of the next).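

Methoxy in place of fluoro on this aromatic carbon, meta to a methoxy group and para to a large group, gives a number 36 percentage points lower from compound 2 to compound 3 (beyond the scatter) in this assay at the concentration tested. The read-out is therefore sensitive to the group at this position, with the rest of compound 2 unchanged. No measurement at hand accounts for the step.

On these data alone, what chloro, methyl or an amine would give on this carbon remains open. So does whether the same change has a step of similar size on the core of compound 1.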